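A Methyl Added to an Inactive Alkyne Antagonist

This account rests on a few compounds, and the source may have more. Where it says the series, first, only, none or still open, it means among the compounds named here.

The compounds here were tested in a functional assay on HEK293 cells for antagonist activity at metabotropic glutamate receptor 5 (Rattus norvegicus); on this read-out higher numbers stand for weaker inhibition and lower numbers for stronger inhibition. Compound 1, with the structure `CCOc1ncc(C#Cc2ccccc2)cn1`, is recorded in this assay as "not active" (no number reported), so no single number places it on the scale; it simply stands outside the measurable range. For the measured compounds named here, compound 2, with the structure `C(#Cc1ncccn1)c1ccccc1`, gives 195 nM in this assay, and this is the only numbered value available. Compound 3, with the structure `CCOc1ncc(C#Cc2ccc(C)cc2)cn1`, has not yet been measured.

Compound 3 differs from compound 1 in one place: methyl in place of hydrogen on an aromatic carbon. Going by the values given here, since compound 1 has no number, no step can be computed, and the size of the change from compound 1 to compound 3 has to be judged without a measured partner. Among the compounds with values here, the only related numbered compound is compound 2, which shows that this kind of alkyne-linked core can reach measurable inhibition, but whether a single methyl lifts compound 1 out of the inactive range is open.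

For compound 3 the inhibitory concentration in this assay is expected to be around 600 nM, with a plausible span from 80 nM to 5000 nM, and a real chance that only a limit is reported again.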

Compound 3, half-maximal inhibitory concentration: "not active" (no number reported)
Compound 3: no number reported; the estimate stays without a comparison.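

In this assay compound 1 gives "not active" (no number reported) and compound 3 gives "not active" (no number reported), so neither side has a number and no step can be read between them. No available information explains this result. The compounds shown leave open whether the methyl of compound 3 changes inhibition at all.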